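A Hydroxy Group Replaces a Long Chain

A few compounds are considered here, and "the series" means these few. Any claim that something is new, unique, unknown or untested is made for them only; others in the source may bear on it.

Compound 3 `CCCCCCCCCCCSC(=S)C1=C(Nc2ccc(Cl)cc2)CC(C)(C)CC1=O` is assessed in a functional assay on PBMC cells (Homo sapiens) for inhibition, read by ELISA, with a stated time of 18 h; on this read-out lower numbers stand for stronger inhibition and higher numbers for weaker inhibition. In this assay compound 3 gives > 20 ug/mL, which is a limit of the assay rather than a number. Two relatives set the scene. Compound 2 `CCCCSC(=S)C1=C(Nc2ccc(Cl)cc2)CC(C)(C)CC1=O` gives > 20 ug/mL, also a limit. Compound 1 `CC1(C)CC(=O)C(C(=S)SCCO)=C(Nc2ccc(Cl)cc2Cl)C1` gives > 20 ug/mL, again a limit. The step that the two limits leave unreadable from compound 2 to compound 3 is therefore unreadable, and all that is known is the limit of > 20 ug/mL in this assay, at which 3 of the 3 values shown sit. Compound 4 `CC1(C)CC(=O)C(C(=S)SCCO)=C(Nc2ccc(Cl)cc2)C1` carries the change (hydroxy in place of nonyl on a saturated chain carbon, two bonds along the chain from a sulfur). Among the measured compounds shown here, compound 1 already bears the hydroxy group and sits at the limit, so no measured step gives a direction. The step that the limit leaves unreadable from compound 3 to compound 4 is expected to stay within that silence. Compound 4 is therefore expected to give 30 ug/mL, within a range from 10 ug/mL to 80 ug/mL, most likely reported as another limit.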

Compound 4, half-maximal inhibitory concentration: > 20 ug/mL
Compound 4: a limit, no number (the forecaster's own chance of this, stated with the estimate: 75%); the middle value does not contradict the limit.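

Compound 4 also stops at a limit of the assay, so its steps from compound 1, compound 2 and compound 3 cannot be read: the limit of > 20 ug/mL in this assay, at which 4 of the 4 values shown sit.

The compounds shown leave open whether any of them has a measurable potency in this assay, and which change to the shared core or its chain would produce one.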